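The compounds below may be only part of what the source reports. "The series", "measured", "known", "first", "only" and "open" are said of these compounds alone.

Measured compounds and values:
- compound 1 `O=C(Nc1ccccc1)C(Cl)Cl`: 130000 nM
- compound 2 `O=C(Nc1ccccc1F)C(Cl)Cl`: 87500 nM
- compound 3 `O=C(Nc1cccc([N+](=O)[O-])c1)C(Cl)Cl`: 18000 nM

Working notes on the series. In a functional assay on A549 cells (Homo sapiens) for antiproliferative activity, read by MTT assay, with a stated time of 72 h (on this read-out higher numbers stand for weaker inhibition and lower numbers for stronger inhibition), compound 1 gives the highest of the three numbers. Compound 2 lies nearest to it, with a 1.5-fold lower number from compound 1 to compound 2 (0.17 log units; within the scatter). Compound 3 lies furthest, with a 7.2-fold lower number from compound 1 to compound 3 (0.86 log units; beyond the scatter).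

The next compound, compound 4 `COc1ccc(NC(=O)C(Cl)Cl)cc1`, differs from compound 1 in one place: methoxy in place of hydrogen on an aromatic carbon. Within the data shown here, no measured step involves a methoxy group, so the two steps from compound 1 are the only guide. The fluoro step stayed within the scatter; the nitro step gave a modest decrease. A methoxy group is neither of these, and nothing in the series shows how this ring position responds on its own. The expectation is therefore a step of little or no size beyond the scatter in this assay, leaning if at all toward a lower number. For compound 4 the estimated value is 100000 nM, with a range from 40000 nM to 250000 nM, which corresponds to an expected step of a 1.3-fold lower number from compound 1 to compound 4 (0.11 log units; within the scatter).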

Compound 4, half-maximal inhibitory concentration: 80900 nM
Beside the measured number, compound 4's estimate is 1.2-fold (0.09 log units) above it; the range from low to high includes it.
By their numbers in this assay, from the lowest: compound 3; then compounds 4, 2 and 1 (each within the scatter of the next).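

In this assay, among these compounds, methoxy on the aromatic carbon para to a group of 6 heavy atoms gives the first reading at this place on the ring: a 1.6-fold lower number from compound 1 to compound 4 (0.21 log units; within the scatter). Among the compounds shown here, this oxygen-bearing group therefore joins fluoro in leaving the number within the scatter, and the nitro step, a 7.2-fold lower number from compound 1 to compound 3 (0.86 log units; beyond the scatter), remains the only change that goes beyond it. No measurement on hand accounts for this result.

Still open, on these data alone, is how an amine, a carboxylic acid or a longer alkoxy chain would read on this same aromatic carbon. Also open, as far as these compounds go, is whether nitro placed there would give a step of similar size, since the series holds no direct comparison of ring positions for a single group.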